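Swapping amino for chloro on a weak inhibitor

A few compounds are considered here, and "the series" means these few. Any claim that something is new, unique, unknown or untested is made for them only; others in the source may bear on it.

In a functional assay on KB cells (Homo sapiens) for inhibition (a higher number here means a weaker inhibitor, a lower number a stronger inhibitor), compound 1 `Cc1ccc(Cn2c(N)nc3cc(Cl)c(Cl)cc32)cc1` gives 50000 nM, and compound 2 `Nc1nc2cc(Cl)c(Cl)cc2n1Cc1ccc(F)cc1` gives 70000 nM, so the two stand level within the scatter. Compound 3 `Cc1ccc(Cn2c(Cl)nc3cc(Cl)c(Cl)cc32)cc1` carries chloro in place of amino on an aromatic carbon, between two ring nitrogen atoms. For the measured compounds named here, the only measured step, a 1.4-fold higher number from compound 1 to compound 2 (0.15 log units; within the scatter), is fluoro in place of methyl at a different place, so it offers no direct guide to this change. With no evidence for a shift, the expected step in this assay is a 1.3-fold lower number from compound 1 to compound 3 (0.10 log units; within the scatter). For compound 3 the estimated value is 40000 nM, with an expected range of 12000 nM to 100000 nM.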

Compound 3, half-maximal inhibitory concentration: > 100000 nM
Compound 3 was reported as a limit; the forecaster's own chance of this, stated with the estimate: 20%; at least 2.5-fold (0.39 log units) between middle value and limit.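

For the compounds shown here, compounds 1 and 2 both carry amino at this place, on an aromatic carbon between two ring nitrogen atoms, so compound 3 gives the first reading of a change there. Chloro in place of amino gives an at least 2.0-fold higher number from compound 1 to compound 3 (0.30 log units; that floor lies within the scatter), which shows no gain in strength in this assay. Compound 3 is reported only as a limit, not as a number: the limit of > 100000 nM in this assay, at which 1 of the 3 values shown sits.

As far as these compounds go, the true size of this step stays open. So does how a methyl, hydroxyl or dimethylamino group at this place would read.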